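The source may report more compounds than this note shows. Statements on the series, on what has been measured and on what is new or still open speak of the compounds shown alone.

Measured so far in a functional assay on MCF7 cells (Homo sapiens) for antiproliferative activity, with a stated time of 72 h; a higher number here means a weaker inhibitor, a lower number a stronger inhibitor:
- compound 1, `Cn1c(N2N=C(c3ccccc3)CC2c2ccc(Cl)cc2)nc(-c2ccccc2)c(C#N)c1=O`, with compound 1 giving 3280 nM
- compound 2, `COc1ccc(C2CC(c3ccccc3)=NN2c2nc(-c3ccccc3)c(C#N)c(=O)n2C)cc1`, with compound 2 giving 18000 nM
- compound 3, `COc1ccc(C2CC(c3ccc(Cl)cc3)=NN2c2nc(-c3ccc(Cl)cc3)c(C#N)c(=O)n2C)cc1`, with compound 3 giving 27300 nM

Compound 1 and compound 2 differ in one place: methoxy in place of chloro on an aromatic carbon. That change gave a 5.5-fold higher number from compound 1 to compound 2 (0.74 log units; beyond the scatter), so in this assay compound 2 is a weaker inhibitor than compound 1. Compound 3 belongs to a different core; the difference between the core of compound 1 and the core of compound 3 is not broken down here. In this assay compound 3 and compound 2 lie within the scatter of each other, so nothing can be said about their order.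

Compound 4, `COc1ccc(C2=NN(c3nc(-c4ccc(Cl)cc4)c(C#N)c(=O)n3C)C(c3ccc(OC)cc3)C2)cc1`, has not yet been measured. It arises from compound 3 by methoxy in place of chloro on an aromatic carbon. This is the same change as the one from compound 1 to compound 2, made at the same kind of place, and it is the only repetition of that change among these compounds. For the measured compounds named here, because a 5.5-fold higher number from compound 1 to compound 2 (0.74 log units; beyond the scatter) was seen when this change was made once, a step of similar direction is expected here, though with only one earlier example its size is uncertain. For compound 4 the expected step is a 2.9-fold higher number from compound 3 to compound 4 (0.47 log units; beyond the scatter). The estimate for compound 4 in this assay is 80000 nM, with a range from 30000 nM to 250000 nM, and since compound 3 already gives a high number, the assay may report only a limit for compound 4.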

Compound 4, half-maximal inhibitory concentration: 99800 nM
The estimate for compound 4 lay 1.2-fold (0.10 log units) below the measured number; low and high end bracket the measured number.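

In this assay, swapping chloro for methoxy once more gave a 3.7-fold higher number from compound 3 to compound 4 (0.56 log units; beyond the scatter), so compound 4 is a weaker inhibitor than compound 3. The change from 4-chlorophenyl to 4-methoxyphenyl therefore moved the number in the same direction on both cores, and the two steps cannot be told apart in size: the same change on two cores in this assay, a 5.5-fold higher number (0.74 log units; beyond the scatter) from compound 1 to compound 2 and a 3.7-fold higher number (0.56 log units; beyond the scatter) from compound 3 to compound 4, 1.5-fold (0.18 log units) apart, within the scatter of two such steps. This shows that, for these two pairs, the effect of the change carried over from one core to the other, but two pairs are too few to make a rule for the whole series, and the numbers alone do not explain why the change weakens these compounds.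

Going by these compounds, what remains open is how other groups in that place would behave, such as an amine, a hydroxyl group, a carboxylic acid or a longer chain such as ethoxy, since chloro and methoxy are the only two compared here. On these data alone, it is also open whether the step would keep its direction and size on a third core, or in any cell line other than the one used in this assay.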